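Removal of the hydroxymethyl from compound 2

A few compounds are considered here, and "the series" means these few. Any claim that something is new, unique, unknown or untested is made for them only; others in the source may bear on it.

Compound 2 `CCC(O)(c1cn(Cc2ccc3c(-c4ccccc4)c(CO)sc3c2)nn1)C(F)(F)F` holds the lower of the two numbers in hand: in an assay on isolated protein for inhibition of Polyunsaturated fatty acid 5-lipoxygenase (Homo sapiens) (a higher number here means a weaker inhibitor, a lower number a stronger inhibitor), compound 2 gives 19 nM, while compound 1 `CC[C@](O)(c1cn(Cc2ccc3c(-c4ccc(F)cc4)c(C(N)=O)sc3c2)nn1)C(F)(F)F` gives 55 nM in this assay, a gap beyond the scatter. Compound 3 `CCC(O)(c1cn(Cc2ccc3c(-c4ccccc4)csc3c2)nn1)C(F)(F)F` is not yet measured in this assay. The change from compound 2 to compound 3 is hydrogen in place of hydroxymethyl on an aromatic carbon. Among the compounds with values here, with no step of this kind among the measured pairs, a small shift toward a higher number, near the edge of the scatter, is expected: a 2.1-fold higher number from compound 2 to compound 3 (0.32 log units; beyond the scatter). Compound 3 is estimated at 40 nM, within 15 nM to 110 nM.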

Compound 3, half-maximal inhibitory concentration: 40 nM
Estimate against measurement, compound 3: no gap at the digits printed, and the stated range covers the measured number.
By their numbers in this assay, from the lowest: compound 2; then compounds 3 and 1 (each within the scatter of the next).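

Hydrogen in place of hydroxymethyl, on the aromatic carbon next to the ring sulfur, is the first single-place step in the series: a 2.1-fold higher number from compound 2 to compound 3 (0.32 log units; beyond the scatter) in this assay. The hydroxymethyl therefore adds only a modest gain at this position, and compound 3 stays active without it at 40 nM. Nothing at hand accounts for the step. Open, on these data alone, is whether an aminomethyl, a carboxylic acid or a longer chain such as hydroxyethyl on this carbon would match compound 2. Also open, as far as these compounds go, is whether the step holds with the fluorophenyl of compound 1.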